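Swapping the Aryl Group on a Sulfonyl Linker

The compounds below may be only part of what the source reports. "The series", "measured", "known", "first", "only" and "open" are said of these compounds alone.

Compound 1 `CC1CCN(c2c(S(=O)(=O)c3cccc(Cl)c3)cnc3cc(Cl)ccc23)CC1` — 92%
Compound 2 `Cc1ccc2ncc(S(=O)(=O)c3cccc(Cl)c3)c(N3CCC(C)CC3)c2c1` — 91%

In an assay on isolated protein for displacement of a labelled ligand from metabotropic glutamate receptor 5 (Homo sapiens), with a stated time of 60 min, tested at 1 uM (a lower number here means less inhibition, a higher number more inhibition at the concentration tested (going by the name of the read-out)), compound 1 gives 92%. This is the higher of the two numbers, yet the gap to compound 2 at 91% lies within the scatter, so the two compounds sit level. Compound 3 `Cc1ccc(S(=O)(=O)c2cnc3cc(Cl)ccc3c2N2CCC(C)CC2)cc1C` differs from compound 1 in one place: 3,4-dimethylphenyl in place of 3-chlorophenyl on a sulfonyl sulfur. Among the compounds with values here, no measured pair shows what such a change does, so the step is expected to be a number 5 percentage points lower from compound 1 to compound 3 (within the scatter), small and within the scatter, if anything slightly downward. Compound 3 is therefore expected to give 87%, in a range from 68% to 97%.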

Compound 3, a percentage reported as inhibition, at one concentration (the size of the read-out at that concentration, not a potency): 86%
For compound 3 the middle estimate is 1 percentage points above the measured one; low and high end bracket the measured number.
By their numbers in this assay, from the lowest: compounds 3, 2 and 1 (each within the scatter of the next).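

In this assay, 3,4-dimethylphenyl in place of 3-chlorophenyl on the sulfonyl sulfur gives a number 6 percentage points lower from compound 1 to compound 3 (within the scatter), so the two compounds sit level. This position therefore accepts an aryl group carrying two methyl groups and no chlorine, with the read-out unchanged beyond normal scatter. No supporting measurement explains this result.

Still open, going by these compounds, is how a pyridine ring, a benzyl group or a phenyl ring bearing a carboxylic acid would fare on the sulfonyl sulfur. Each number also comes from a single concentration, so it shows no difference in potency between these compounds.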